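The source may hold more compounds than are shown below. What is called first, only, known or untested is meant among the compounds shown, and "the series" means these compounds.

Among the compounds with values here, compound 1 `CC(C)n1cnc2c(Nc3cccc(Cl)c3)nc(NCOCc3ccc(C(=O)Nc4ccccc4N)cc3)nc21` and compound 2 `Nc1ccccc1NC(=O)/C=C/c1ccc(Cn2cnc3c(Nc4cccc(Cl)c4)nc(Cl)nc32)cc1` are the two measured members of this set. In a functional assay on HCT-116 cells (Homo sapiens) for antiproliferative activity, read by CCK-8 assay, with a stated time of 72 h, tested at 2 uM (on this read-out higher numbers stand for a stronger effect at the one concentration tested and lower numbers for a weaker effect), compound 1 gives 7.12%, and compound 2 gives 12.9%; the two numbers lie within the usual scatter of each other, so neither stands apart. Compound 3 `CC(C)n1cnc2c(Nc3ccccc3)nc(NCOCc3ccc(C(=O)Nc4ccccc4N)cc3)nc21` is not yet measured. Against compound 1 it carries a single change: hydrogen in place of chloro on an aromatic carbon. With only two low, near-identical numbers behind it, the step is expected to stay within the scatter, estimated as a number 0.1 percentage points lower from compound 1 to compound 3 (within the scatter). Compound 3 is therefore expected to give about 7% in this assay, with a range from 0% to 20%.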

Compound 3, a percentage reported as inhibition, at one concentration (the size of the read-out at that concentration, not a potency): 6.85%
Compound 3: the middle estimate sits 0.2 percentage points above what was measured; the range from low to high includes it.
By their numbers in this assay, from the lowest: compounds 3, 1 and 2 (each within the scatter of the next).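

In this assay, within the data shown here, the change from 3-chlorophenyl to phenyl gives the first single-place comparison (a number 0.3 percentage points lower from compound 1 to compound 3 (within the scatter)), and it shows that, for this pair, the chloro makes no readable difference at the one concentration tested. Both values lie low on the read-out, so this pair shows no gain or loss from the chloro. No measurement bears on why this is so. From the compounds shown here alone, whether a methoxy, an amine or a carboxylic acid at the same aromatic carbon would move the number beyond the scatter stays open.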